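A few compounds are considered here, and "the series" means these few. Any claim that something is new, unique, unknown or untested is made for them only; others in the source may bear on it.

In a functional assay (strain AB) with Danio rerio as the target, read by microscopy, with a stated time of 1 h (a higher number here means that more compound is needed for the effect, a lower number that less compound is needed), compound 1 (`CCN1CCc2c(sc(NC(=O)Nc3ccccc3)c2C(N)=O)C1`) gives > 25000 nM, which is a limit of the assay and not a number. Two relatives share its core. Compound 2 (`CCN1CCc2c(sc(NC(=O)Nc3cccc(Cl)c3Cl)c2C(N)=O)C1`) gives 17400 nM, and compound 3 (`CC(C)(C)OC(=O)CCCN1CCc2c(sc(NC(=O)Nc3ccc(Cl)cc3)c2C(N)=O)C1`) gives 560 nM. Within the data shown here, the one measured step that changes a single place is an at least 1.4-fold lower number from compound 1 to compound 2 (0.15 log units; that floor lies within the scatter). Among the measured compounds shown here, compound 3 differs from compound 1 in more than one place, so it offers no clean step.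

Compound 4 (`CCN1CCc2c(sc(NC(=O)CN3CCCCC3)c2C(N)=O)C1`) comes from compound 1 by a different kind of change, with (piperidin-1-yl)methyl in place of anilino on a carbonyl carbon. The measured step only alters the aromatic ring of the anilino group, whereas here the whole anilino group leaves, so that step bears on this change only loosely. For the measured compounds named here, no measured compound carries (piperidin-1-yl)methyl on this carbonyl carbon.

The expectation therefore rests on compound 1, whose > 25000 nM is a limit, and it points to no clear movement in this assay in either direction. The estimated step is a number no higher from compound 1 to compound 4 (the limit leaves the size open), which is expected to stay within the scatter, although its uncertainty is wide. For compound 4 the expected value is an estimated 25000 nM, with a range from 8000 nM to 80000 nM.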

Compound 4, half-maximal effective concentration: > 25000 nM
Compound 4 ended at the assay's limit; the forecaster's own chance of this, stated with the estimate: 60%; the middle value lies on the limit itself.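

In this assay compound 4 gives > 25000 nM as a limit of the assay and not a number. Compound 1 also stands at a limit, so no step can be read from compound 1 to compound 4: the limit of > 25000 nM in this assay, at which 2 of the 4 values shown sit. The compounds shown leave open whether in this assay anilino and (piperidin-1-yl)methyl on this carbonyl carbon differ at all.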